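The compounds below may be only part of what the source reports. "The series", "measured", "known", "first", "only" and "open" are said of these compounds alone.

Measured so far:
- compound 1 `O=C1C(Nc2ccc(-c3ccc(Cl)cc3)cc2)=CC(=O)c2ncncc21`: 10100 nM
- compound 2 `O=C1C(Nc2cccc(-c3ccccc3)c2)=CC(=O)c2ncncc21`: 5100 nM
- compound 3 `CN1CCN(c2ccc(NC3=CC(=O)c4ncncc4C3=O)cc2)CC1`: 900 nM

All three were tested in a functional assay on BXPC-3 cells (Homo sapiens) for cytotoxicity, read by MTT assay, with a stated time of 72 h; on this read-out lower numbers stand for stronger inhibition and higher numbers for weaker inhibition. Compound 3 has the lowest number of the three at 900 nM, and the numbers of compound 2 and compound 1 both lie above it, beyond the scatter.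

Compound 4 `O=C1C(Nc2ccc(C3CCCCC3)cc2)=CC(=O)c2ncncc21` has not yet been measured. It carries cyclohexyl in place of 4-methylpiperazin-1-yl on an aromatic carbon.

Within the data shown here, only one measured step bears on this change. It is an 11-fold lower number from compound 1 to compound 3 (1.05 log units; beyond the scatter), a large step beyond the scatter, in which 4-methylpiperazin-1-yl replaced 4-chlorophenyl. Removing 4-methylpiperazin-1-yl from compound 3 is therefore expected to raise the number in this assay. Cyclohexyl is a different group from 4-chlorophenyl and has no measured step of its own, so the rise is expected to be somewhat smaller and remains uncertain. The expected change is a 5.6-fold higher number from compound 3 to compound 4 (0.74 log units; beyond the scatter). Compound 4 is estimated at 5000 nM, with an expected range from 1800 nM to 14000 nM.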

Compound 4, half-maximal inhibitory concentration: 500 nM
For compound 4 the middle estimate is 10-fold (1.00 log units) above the measured one; the whole stated range lies above it.
By their numbers in this assay, from the lowest: compounds 4 and 3 (each within the scatter of the next); then compounds 2 and 1 (each within the scatter of the next).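

In this assay, cyclohexyl in place of 4-methylpiperazin-1-yl gives a 1.8-fold lower number from compound 3 to compound 4 (0.26 log units; within the scatter), so at this position the two groups cannot be told apart, even though cyclohexyl has no nitrogen and no hydrogen-bond acceptors. Cyclohexyl in place of 4-chlorophenyl gives a 20-fold lower number from compound 1 to compound 4 (1.31 log units; beyond the scatter), so the large gain seen earlier with 4-methylpiperazin-1-yl also appears with a six-membered non-aromatic ring of carbon only. Nothing measured here explains these results.

Still open, as far as these compounds go, is whether a smaller ring such as cyclopentyl, an open chain such as n-butyl, or a simple amine such as dimethylamino would give numbers in the same range at this position. From the compounds shown here alone, it is also open whether a morpholine ring, with oxygen in place of one ring nitrogen, would fit the same picture.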